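Changing the ring on compound 3

The source may hold more compounds than are shown below. What is called first, only, known or untested is meant among the compounds shown, and "the series" means these compounds.

In an ADME assay on MDCK cells (Canis lupus familiaris) for cytotoxicity, with a stated time of 48 h (on this read-out higher numbers stand for lower toxicity in this test and lower numbers for higher toxicity in this test), compound 3 `C=C(C(=O)Nc1ccc(B(O)O)cc1)[C@@H]1CC[C@H](C)[C@@H]2CC(=O)C(C)=C2C1` gives 939 uM. That is within the scatter of compound 1 `C=C(C(=O)OC)[C@@H]1CC[C@H](C)[C@H]2C(=C(C)C(=O)[C@H]2NC(=O)C(C)CCl)C1` at 735 uM and clearly higher than compound 2 `C=C(C(=O)OC)[C@@H]1CC[C@H](C)[C@H]2C(=C(C)C(=O)[C@H]2NC(=O)c2ccc(B(O)O)cc2)C1` at 188 uM. Compound 4 `C=C(C(=O)Nc1ncc(B(O)O)cn1)[C@@H]1CC[C@H](C)[C@@H]2CC(=O)C(C)=C2C1` differs from compound 3 at one place, on an amide-type nitrogen: a group of 9 heavy atoms (4 carbon, 1 boron, 2 nitrogen, 2 oxygen; one six-membered aromatic ring with 2 hetero atoms) in place of a group of 9 heavy atoms (6 carbon, 1 boron, 2 oxygen; one six-membered aromatic ring of carbon only), on an amide-type nitrogen. Among the compounds with values here, the only measured step, a 3.9-fold lower number from compound 1 to compound 2 (0.59 log units; beyond the scatter), is a different swap, made on a carbonyl carbon, and it offers only loose guidance. Within the data shown here, no measured pair tests a ring with hetero atoms against a ring of carbon only. No step beyond the scatter is therefore expected in this assay. The estimated change is a 1.2-fold lower number from compound 3 to compound 4 (0.07 log units; within the scatter). Compound 4 is expected at 800 uM, with a likely range of 300 uM to 2000 uM.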

Compound 4, half-maximal toxic concentration: 315 uM
For compound 4 the middle estimate is 2.5-fold (0.40 log units) above the measured one, and the stated range covers the measured number.
By their numbers in this assay, from the lowest: compounds 2 and 4 (each within the scatter of the next); then compounds 1 and 3 (each within the scatter of the next).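

On the amide-type nitrogen, replacing the six-membered aromatic ring of carbon only with one carrying 2 hetero atoms gives, in this assay, a 3.0-fold lower number from compound 3 to compound 4 (0.47 log units; beyond the scatter). Within the data shown here, this is the first measured pair to show that the atoms within this ring can shift the read-out, even though the entering and leaving groups are the same size and the entering group counts more hydrogen-bond acceptors. No measurement shown here explains the shift.

As far as these compounds go, it remains open where a pyridine ring, with a single ring nitrogen, would stand relative to compound 3 and compound 4. From the compounds shown here alone, the effect of the same ring swap on a different core is also open.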